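The compounds below may be only part of what the source reports. "The series", "measured", "known", "first", "only" and "open" are said of these compounds alone.

Compound 1, `N#CC1=C(N)Oc2c(c3nc4ccccc4nc3c3ccccc23)C12C(=O)N(Cc1cnnn1-c1ccc(Cl)cc1)c1ccccc12`, and compound 2, `N#CC1=C(N)Oc2c(c3nc4ccccc4nc3c3ccccc23)C12C(=O)N(Cc1cnnn1-c1ccccc1Cl)c1ccccc12`, share a core and differ by 2-chlorophenyl in place of 4-chlorophenyl on an aromatic nitrogen. In a functional assay on MCF7 cells (Homo sapiens) for antiproliferative activity, read by MTT assay, with a stated time of 48 h (a lower number here means a stronger inhibitor, a higher number a weaker inhibitor), compound 1 gives > 50000 nM, which is a limit of the assay rather than a number. Compound 2 likewise gives > 50000 nM, again a limit. The step that the two limits leave unreadable from compound 1 to compound 2 therefore cannot be sized, because both values sit at the limit of > 50000 nM in this assay, at which 3 of the 3 values shown sit. Compound 3, `N#CC1=C(N)Oc2c(N)cc3nc4ccccc4nc3c2C12C(=O)N(Cc1cnnn1-c1ccc(Cl)cc1)c1ccccc12`, carries a different core; how its core differs from that of compound 1 is not broken down here. In this assay compound 3 gives > 50000 nM, once more a limit. Compound 4, `N#CC1=C(N)Oc2c(N)cc3nc4ccccc4nc3c2C12C(=O)N(Cc1cnnn1-c1ccccc1Cl)c1ccccc12`, repeats the same change on the core of compound 3: 2-chlorophenyl in place of 4-chlorophenyl on an aromatic nitrogen. Since no value among the three rises above the limit, compound 4 is expected to remain there too, an expected step that the limit leaves unreadable from compound 3 to compound 4. The estimate for compound 4 in this assay is 100000 nM, expected to lie between 30000 nM and 400000 nM.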

Compound 4, half-maximal inhibitory concentration: 34400 nM
The estimate for compound 4 lay 2.9-fold (0.46 log units) above the measured number; low and high end bracket the measured number.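

On the core of compound 3, 2-chlorophenyl in place of 4-chlorophenyl gives, in this assay, an at least 1.4-fold lower number from compound 3 to compound 4 (0.16 log units; that floor lies within the scatter), and compound 4 is the only compound shown whose result is a number rather than a limit, at 34400 nM. From the compounds shown here alone, on the core of compound 1 the same change cannot be read, since the values on both sides are limits: the limit of > 50000 nM in this assay, at which 3 of the 4 values shown sit. Whether the change acts alike on the two cores therefore stays unknown, and with a floor that lies within the scatter, this step alone does not establish a real difference.

The compounds shown leave open how a plain phenyl would read on the aromatic nitrogen of either core. They also leave open what an amine or a carboxylic acid in place of the chlorine would give.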